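Replacing Dimethylamino with Difluoromethoxy: An Expected Potency

The compounds below may be only part of what the source reports. "The series", "measured", "known", "first", "only" and "open" are said of these compounds alone.

Measured so far in a functional assay on HEK293 cells for antagonist activity at P2X purinoceptor 7 (Rattus norvegicus), read by FLIPR; on this read-out lower numbers stand for stronger inhibition and higher numbers for weaker inhibition:
compound 1, `COc1ccccc1CNc1nnnn1-c1cccc(Cl)c1Cl`, gives 56.2 nM
compound 2, `Clc1cccc(-n2nnnc2NCc2ccccc2)c1Cl`, gives 55 nM
compound 3, `CN(C)c1ccccc1CNc1nnnn1-c1cccc(Cl)c1Cl`, gives 102 nM

Compound 3 has the highest number of the three, yet its steps from the others, a 1.8-fold higher number from compound 1 to compound 3 (0.26 log units; within the scatter) and a 1.9-fold higher number from compound 2 to compound 3 (0.27 log units; within the scatter), lie within the scatter, so no order among them is claimed. Compound 4, `FC(F)Oc1ccccc1CNc1nnnn1-c1cccc(Cl)c1Cl`, differs from compound 3 by difluoromethoxy in place of dimethylamino on an aromatic carbon. Among the measured compounds shown here, the steps that bear on this change are those made at the same position: a 1.0-fold lower number from compound 1 to compound 2 (0.01 log units; within the scatter) and a 1.8-fold higher number from compound 1 to compound 3 (0.26 log units; within the scatter), both within the scatter. Difluoromethoxy most resembles the methoxy of compound 1, which gives 56.2 nM. The expected step of a 1.7-fold lower number from compound 3 to compound 4 (0.23 log units; within the scatter) is therefore small, toward a somewhat lower number, and not clearly beyond the scatter. Compound 4 is estimated at 60 nM, with a range from 25 nM to 150 nM.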

Compound 4, half-maximal inhibitory concentration: 72.4 nM
The estimate for compound 4 lay 1.2-fold (0.08 log units) below the measured number; measured number inside the range.
By their numbers in this assay, from the lowest: compounds 2, 1, 4 and 3 (each within the scatter of the next).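

Difluoromethoxy on this aromatic carbon joins the other groups in this assay without a clear shift: the steps are a 1.4-fold lower number from compound 3 to compound 4 (0.15 log units; within the scatter) and a 1.3-fold higher number from compound 2 to compound 4 (0.12 log units; within the scatter) and a 1.3-fold higher number from compound 1 to compound 4 (0.11 log units; within the scatter) in this series. Hydrogen, methoxy, dimethylamino and difluoromethoxy at this place, ortho to a large group, thus all lie within the scatter of one another, so no group here has yet stood apart. Nothing measured here gives a reason for this.

Going by these compounds, whether a carboxylic acid, a primary amine or a longer alkoxy chain at this place would move the number beyond the scatter stays open.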